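The source may hold more compounds than are shown below. What is called first, only, known or untested is meant among the compounds shown, and "the series" means these compounds.

Compounds measured so far:
compound 1 `CC1(C)OC(=O)C2(C(=O)O1)C(c1ccc(F)cc1)C(c1ccccc1)=NN2c1ccccc1` — 1470000 nM
compound 2 `CN(C)c1ccc(C2C(c3ccccc3)=NN(c3cccc(Cl)c3)C23C(=O)OC(C)(C)OC3=O)cc1` — 430000 nM
compound 3 `CC1(C)OC(=O)C2(C(=O)O1)C(c1cccs1)C(c1ccccc1)=NN2c1cccc(Cl)c1` — 321000 nM

In a functional assay on aorta (Rattus norvegicus, strain Wistar) for inhibition (a higher number here means a weaker inhibitor, a lower number a stronger inhibitor), compound 1 gives the highest number of the three, so it is the weakest inhibitor of this set; compound 2 and compound 3 both lie lower, each beyond the scatter from compound 1. Compound 4 `Cc1ccc(C2C(c3ccccc3)=NN(c3ccccc3)C23C(=O)OC(C)(C)OC3=O)o1` differs from compound 1 in one place: 5-methylfuran-2-yl in place of 4-fluorophenyl on a saturated ring carbon. Going by the values given here, one measured step bears on a swap of this kind at the same saturated ring carbon, a five-membered heteroaryl entering in place of a six-membered aryl: a 1.3-fold lower number from compound 2 to compound 3 (0.13 log units; within the scatter). Since that step stayed within the scatter, a step of similar size is expected here, a 1.5-fold lower number from compound 1 to compound 4 (0.17 log units; within the scatter). Compound 4 is therefore estimated at 1000000 nM, within a range from 350000 nM to 3000000 nM.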

Compound 4, half-maximal inhibitory concentration: 719000 nM
Compound 4: the middle estimate sits 1.4-fold (0.14 log units) above what was measured; measured number inside the range.
By their numbers in this assay, from the lowest: compounds 3, 2 and 4 (each within the scatter of the next, the first and the last beyond it); then compound 1.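

In this assay, replacing 4-fluorophenyl with 5-methylfuran-2-yl gives a 2.0-fold lower number from compound 1 to compound 4 (0.31 log units; beyond the scatter), a modest step but the first at this saturated ring carbon to pass beyond the scatter. The swap changes the ring size, removes the fluorine and adds a ring oxygen and a methyl together, so the step cannot be assigned to any one of these. Nothing measured here explains the step. Still open, going by these compounds, is how a plain furan-2-yl would compare with 5-methylfuran-2-yl, which would test the methyl alone. On these data alone, the effect of a carboxylic acid on the ring at this position is also open.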